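The compounds below may be only part of what the source reports. "The series", "measured", "known", "first", "only" and "open" are said of these compounds alone.

Measured in a functional assay on PC-3 cells (Homo sapiens) for inhibition; on this read-out lower numbers stand for stronger inhibition and higher numbers for weaker inhibition:
Compound 1 `COc1cc2nc(N3CCN(C(=O)c4ccc(C(C)(C)C)cc4)CC3)nc(N)c2cc1OC` gives 47000 nM.
Compound 2 `COc1cc2nc(N3CCN(C(=O)c4ccc(C(F)(F)F)cc4)CC3)nc(N)c2cc1OC` gives only a limit of the assay, > 100000 nM.
Compound 3 `COc1cc2nc(N3CCN(S(=O)(=O)c4ccccc4[N+](=O)[O-])CC3)nc(N)c2cc1OC` gives 35000 nM.

Of the two compounds that returned a number in this assay, compound 3 stands lowest, with compound 1 nearest; the gap between them lies within the scatter, so the two cannot be ordered against each other. Compound 4 `COc1cc2nc(N3CCN(S(=O)(=O)c4ccc(C(F)(F)F)cc4)CC3)nc(N)c2cc1OC` has not yet been measured in this assay. It differs from compound 3 in one place: 4-(trifluoromethyl)phenyl in place of 2-nitrophenyl on a sulfonyl sulfur.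

For the measured compounds named here, only one measured step bears on this change, and only loosely: an at least 2.1-fold higher number from compound 1 to compound 2 (0.32 log units; beyond the scatter). That step introduced a trifluoromethyl group on an aromatic ring, as the change to compound 4 does, and weakened inhibition; its size is known only as a lower bound, since the value of compound 2 sits at the limit of > 100000 nM in this assay, at which 1 of the 3 values shown sits. Going by the values given here, the departure of the 2-nitrophenyl group has no measured counterpart; the only comparison is that compound 3 and compound 1, which differ in both the linking group and the aryl group, sit within the scatter of each other.

Weaker inhibition is therefore expected for compound 4, with the expected step being a 2.0-fold higher number from compound 3 to compound 4 (0.30 log units; within the scatter). Compound 4 is estimated at 70000 nM, within a range from 25000 nM to 200000 nM.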

Compound 4, half-maximal inhibitory concentration: 27000 nM
The estimate for compound 4 lay 2.6-fold (0.41 log units) above the measured number; low and high end bracket the measured number.
By their numbers in this assay, from the lowest: compounds 4, 3 and 1 (each within the scatter of the next). At a limit, above all of these: compound 2.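

In this assay, 4-(trifluoromethyl)phenyl in place of 2-nitrophenyl on a sulfonyl sulfur gives a 1.3-fold lower number from compound 3 to compound 4 (0.11 log units; within the scatter), so compound 3 and compound 4 cannot be told apart, and the hydrogen-bond acceptors counted in 2-nitrophenyl are not needed to keep the number at this level. A trifluoromethyl group on the aromatic ring therefore does not go with weaker inhibition in every setting: the earlier at least 2.1-fold higher number from compound 1 to compound 2 (0.32 log units; beyond the scatter) is not repeated on the sulfonyl sulfur, where the trifluoromethyl-bearing compound 4 stays level with compound 3. Compound 2 is held at a limit of the assay, so the size of that earlier step remains open at its upper end: the limit of > 100000 nM in this assay, at which 1 of the 4 values shown sits.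

The compounds shown do not separate the effect of the group on the aromatic ring from that of its place on the ring, as a 4-nitrophenyl or a 2-(trifluoromethyl)phenyl group on the sulfonyl sulfur would. They also leave open whether an amine or a carboxylic acid on that ring, or an alkyl chain directly on the sulfonyl sulfur, would move the number beyond the scatter.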